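Adding a methyl to the amino acid side chain of compound 1

A few compounds are considered here, and "the series" means these few. Any claim that something is new, unique, unknown or untested is made for them only; others in the source may bear on it.

Measured compounds:
- compound 1, `C=C1[C@H](C)CCC[C@]1(C)CC/C(C)=C/CC1=C(O)C(=O)C=C(N[C@@H](CO)C(=O)O)C1=O`: > 10 ug/mL
- compound 2, `COC1=CC(=O)C(O)=C(C/C=C(\C)CC[C@@]2(C)CCC=C(C)[C@H]2C)C1=O`: > 10 ug/mL
- compound 3, `CC1=CCC[C@](C)(CC/C(C)=C/CC2=C(O)C(=O)C=C(NCC(=O)O)C2=O)[C@@H]1C`: 5.4 ug/mL

Three quinone-bearing terpenoids have been tested in an ADME assay on KB cells (Homo sapiens) for cytotoxicity, with a stated time of 48 h; on this read-out higher numbers stand for weaker inhibition and lower numbers for stronger inhibition. In this assay compound 1 gives > 10 ug/mL, which is a limit of the assay and not a number. Compound 2 likewise gives > 10 ug/mL, again only a limit. Among the compounds with values here, compound 3 is the one measured compound with a number, 5.4 ug/mL. Within the data shown here, the one step that connects two measured compounds, an at least 1.8-fold lower number from compound 2 to compound 3 (0.26 log units; that floor lies within the scatter), concerns a change on the quinone ring and not a change on an amino acid side chain, so it does not bear on the step at hand.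

The unmeasured compound 4, `C=C1[C@H](C)CCC[C@]1(C)CC/C(C)=C/CC1=C(O)C(=O)C=C(N[C@H](C(=O)O)[C@@H](C)O)C1=O`, differs from compound 1 by methyl in place of hydrogen on a saturated chain carbon bound to an oxygen on a saturated carbon and a saturated chain carbon. This leaves the core, the terpene chain and the acid untouched. Among the measured compounds shown here, nothing among the measured steps speaks to such a change, and with the limit of > 10 ug/mL in this assay, at which 2 of the 3 values shown sit, the starting point itself is only a limit. No movement beyond the scatter is therefore expected, and compound 4 is most likely to return the same limit.

The estimated step that the limit leaves unreadable from compound 1 to compound 4 is expected to be small. Compound 4 is estimated at 15 ug/mL, within 7 ug/mL to 40 ug/mL.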

Compound 4, half-maximal inhibitory concentration: > 10 ug/mL
Compound 4 gave a limit, no number (the forecaster's own chance of this, stated with the estimate: 75%); the middle value lies beyond the limit too.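

In this assay compound 4 gives > 10 ug/mL as a limit and not a number. Compound 1 also sits at a limit, so the step from compound 1 to compound 4 cannot be read: the limit of > 10 ug/mL in this assay, at which 3 of the 4 values shown sit.

As far as these compounds go, whether adding the methyl to the side chain changes the inhibition at all stays open.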